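The source may hold more compounds than are shown below. What is called first, only, known or untested is meant among the compounds shown, and "the series" means these compounds.

Compound 2 `COC(=O)[C@@]1(C)CCC=C2[C@@H]1CC[C@@H](C)[C@]2(C)Cc1c[nH]c2ccc(OC)cc12` stands at the lower of the two numbers recorded in a functional assay on A549 cells (Homo sapiens) for inhibition, read by sulforhodamine B assay, with a stated time of 48 h (on this read-out lower numbers stand for stronger inhibition of growth and higher numbers for weaker inhibition of growth), where compound 2 gives 2200 nM. Within the data shown here, compound 1 `COC(=O)[C@@]1(C)CCC=C2[C@@H]1CC[C@@H](C)[C@]2(C)Cc1c[nH]c2ccc(Cl)cc12` gives 16000 nM in this assay, and the single measured step, a 7.3-fold lower number from compound 1 to compound 2 (0.86 log units; beyond the scatter), concerns a change on the six-membered ring of the fused system, not the five-membered ring. Compound 3 `COC(=O)[C@@]1(C)CCC=C2[C@@H]1CC[C@@H](C)[C@]2(C)Cc1c(C)[nH]c2ccc(OC)cc12` differs from compound 2 by methyl in place of hydrogen on an aromatic carbon, the methyl entering on an aromatic carbon of the five-membered aromatic ring with one nitrogen, next to the ring nitrogen and next to the ring atom that bears a large group. Among the measured compounds shown here, no measured step touches a change of this kind, so the step from compound 1 to compound 2 offers no guidance on its size or direction. Compound 3 is therefore expected to stay close to compound 2 in this assay, with an expected step of a 1.1-fold higher number from compound 2 to compound 3 (0.06 log units; within the scatter) that need not exceed the scatter. The estimate for compound 3 is 2500 nM, with a range from 800 nM to 8000 nM.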

Compound 3, concentration for 50% growth inhibition: 16000 nM
For compound 3 the middle estimate is 6.4-fold (0.81 log units) below the measured one; the whole stated range lies below it.
By their numbers in this assay, from the lowest: compound 2; then compounds 1 and 3 (each within the scatter of the next).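

The aromatic carbon of the five-membered ring, next to the ring nitrogen and next to the ring atom that bears a large group, proves sensitive to substitution in this assay and does not tolerate every change. Methyl in place of hydrogen there gives a 7.3-fold higher number from compound 2 to compound 3 (0.86 log units; beyond the scatter) and weakens growth inhibition, the first measured sign that this position matters at all. Nothing in the available data accounts for this loss.

This single step, taken with the methoxy of compound 2 in place, does not show whether the same methyl would weaken growth inhibition with the chloro of compound 1. It also leaves open whether a longer chain such as ethyl, or a group such as hydroxymethyl or an amine, would fare alike at this carbon.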